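A few compounds are considered here, and "the series" means these few. Any claim that something is new, unique, unknown or untested is made for them only; others in the source may bear on it.

Measured compounds:
Compound 1, `Cc1cc(CCC(=O)O)ccc1-c1noc(-c2ccc(OC(C)C)c(C(F)(F)F)c2)n1`, in a functional assay on CHO cells with sphingosine 1-phosphate receptor 2 (Homo sapiens) as the target, read by GTPgammaS binding (a lower number here means that less compound is needed, a higher number that more compound is needed for the effect), gives > 10000 nM, a limit of the assay.
Compound 2, `COc1cc(-c2nc(-c3ccc(CCC(=O)O)cc3C)no2)ccc1OC(C)C`, in this assay gives > 10000 nM, likewise a limit.

Compound 2 thus stands only at a limit in this assay, and no number is known for it. The same holds for compound 1, so that both values sit at the limit of > 10000 nM in this assay, at which 2 of the 2 values shown sit. Going by the values given here, the one measured step, a step that the two limits leave unreadable from compound 1 to compound 2, therefore has no readable size: the two limits leave open whether the exchange at that aromatic carbon changed anything at all.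

Compound 3, `Cc1cc(CCC(=O)O)ccc1-c1noc(-c2ccc(OC(C)C)c(C#N)c2)n1`, differs from compound 2 in one place: cyano in place of methoxy on an aromatic carbon. Among the compounds with values here, the only step that bears on this change is the one from compound 1 to compound 2, which also altered the substituent at this carbon, and it left both compounds at the limit. Nothing here points to a readable gain or loss. Compound 3 is therefore expected to remain at the limit, with an estimate of 20000 nM and a range from 5000 nM to 100000 nM. The step that the limit leaves unreadable from compound 2 to compound 3 is expected to lie within the scatter, if it becomes readable at all.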

Compound 3, half-maximal effective concentration: > 10000 nM
Compound 3: a limit, no number (the forecaster's own chance of this, stated with the estimate: 85%); the middle value is on the limit's open side.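

In this assay compound 3 gives > 10000 nM, a limit of the assay. Going by these compounds alone, no step among compound 1, compound 2 and compound 3 can therefore be read. These compounds leave open whether trifluoromethyl, methoxy and cyano on that aromatic carbon differ at all, because all three compounds share one limit: the limit of > 10000 nM in this assay, at which 3 of the 3 values shown sit.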